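A few compounds are considered here, and "the series" means these few. Any claim that something is new, unique, unknown or untested is made for them only; others in the source may bear on it.

Compound 1 `COc1cccc(NC(=O)COc2ccc3cc(/C=C4/SC(=O)NC4=O)ccc3c2)c1` carries a 3-methoxyphenyl on its amide-type nitrogen. Within the data shown here, in an assay on isolated protein for inhibition of histone deacetylase 8 (Homo sapiens), with a stated time of 1 h (on this read-out higher numbers stand for weaker inhibition and lower numbers for stronger inhibition), compound 1 gives 7600 nM, the highest of the three numbers so far. Compound 2 `O=C(COc1ccc2cc(/C=C3/SC(=O)NC3=O)ccc2c1)Nc1cccc(F)n1` gives 7200 nM in this assay, and compound 3 `O=C(COc1ccc2cc(/C=C3/SC(=O)NC3=O)ccc2c1)Nc1ccc([N+](=O)[O-])cc1` gives 4000 nM. Both a 1.1-fold lower number from compound 1 to compound 2 (0.02 log units; within the scatter) and a 1.9-fold lower number from compound 1 to compound 3 (0.28 log units; within the scatter) stay within the scatter, as does a 1.8-fold lower number from compound 2 to compound 3 (0.26 log units; within the scatter). Compound 4 `Cc1cccc(NC(=O)COc2ccc3cc(/C=C4/SC(=O)NC4=O)ccc3c2)n1` differs from compound 1 by 6-methylpyridin-2-yl in place of 3-methoxyphenyl on an amide-type nitrogen. Among the measured compounds shown here, the nearest precedent is compound 2, whose 6-fluoropyridin-2-yl also sits on the amide-type nitrogen, and there a 1.1-fold lower number from compound 1 to compound 2 (0.02 log units; within the scatter) was within the scatter. The expected step is therefore a 1.1-fold lower number from compound 1 to compound 4 (0.04 log units; within the scatter), no larger than the scatter. Compound 4 is thus estimated to give 7000 nM in this assay, between 3500 nM and 14000 nM.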

Compound 4, half-maximal inhibitory concentration: 7500 nM
The estimate for compound 4 lay 1.1-fold (0.03 log units) below the measured number, within the range that was stated.
By their numbers in this assay, from the lowest: compounds 3, 2, 4 and 1 (each within the scatter of the next).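

Methyl in place of fluoro on an aromatic carbon is a change the earlier compounds did not include, and a 1.0-fold higher number from compound 2 to compound 4 (0.02 log units; within the scatter) keeps this swap within the scatter in this assay. The 6-methylpyridin-2-yl group also stays within the scatter of 3-methoxyphenyl, with a 1.0-fold lower number from compound 1 to compound 4 (0.01 log units; within the scatter) as the step, and of 4-nitrophenyl, with a 1.9-fold higher number from compound 3 to compound 4 (0.27 log units; within the scatter) as the step. No measurement at hand offers an explanation for these steps. On these data alone, whether an aminomethyl or carboxylic acid group on the amide-type nitrogen would give a step beyond the scatter remains open.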